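A Nitro-to-Amino Swap on Two Related Cores

The source may report more compounds than this note shows. Statements on the series, on what has been measured and on what is new or still open speak of the compounds shown alone.

Compound 1 `COc1ccc(/C=C\c2ccc3ccccc3c2)cc1[N+](=O)[O-]` and compound 2 `COc1ccc(/C=C\c2ccc3ccccc3c2)cc1N` share one core and differ in a single place: amino in place of nitro on an aromatic carbon. Both were tested in a functional assay on A549 cells (Homo sapiens) for inhibition; on this read-out higher numbers stand for weaker inhibition and lower numbers for stronger inhibition. There compound 1 gives only a limit of the assay, > 20000 nM. Compound 2 likewise gives only a limit, > 20000 nM. The step that the two limits leave unreadable from compound 1 to compound 2 therefore has no readable size.

Compound 3 `COc1cc(/C=C/c2ccc(N(C)C)c([N+](=O)[O-])c2)cc(OC)c1OC` rests on a different core; how that core differs from the core of compound 1 is not broken down here. In this assay compound 3 also gives only a limit, > 5000 nM.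

Compound 4 `COc1cc(/C=C/c2ccc(N(C)C)c(N)c2)cc(OC)c1OC` has not yet been measured and differs from compound 3 by amino in place of nitro on an aromatic carbon. Within the data shown here, this is the same kind of change as the one from compound 1 to compound 2, though the surroundings differ: in compound 2 the amino is ortho to a methoxy group, whereas in compound 4 it is ortho to a dimethylamino group.

Among the measured compounds shown here, every value so far sits at a limit, as the limit of > 20000 nM in this assay, at which 2 of the 3 values shown sit, and the limit of > 5000 nM in this assay, at which 1 of the 3 values shown sits, show, so the measured step supplies no size to carry over. The step is nonetheless expected to be small: a step that the limit leaves unreadable from compound 3 to compound 4. That expectation rests on compound 3 giving > 5000 nM. It also rests on the unreadable step that the two limits leave unreadable from compound 1 to compound 2. Compound 4 is thus estimated to give about 10000 nM, within a range from 2000 nM to 50000 nM, and may well again appear only as a limit.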

Compound 4, half-maximal inhibitory concentration: 1520 nM
The estimate for compound 4 lay 6.6-fold (0.82 log units) above the measured number, and the stated range ends above it.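

In this assay, amino in place of nitro on the core of compound 3 gives an at least 3.2-fold lower number from compound 3 to compound 4 (0.51 log units; beyond the scatter), so on this core the swap yields a real measured number where the nitro compound showed only a limit. That step is a minimum and its true size stays unknown, since the nitro compound sits at a limit: the limit of > 5000 nM in this assay, at which 1 of the 4 values shown sits. On the core of compound 1 the same swap has no readable step, so this pair of cores neither shows that the gain carries over from one core to the other nor that it fails to, since compound 1 and compound 2 both sit at a limit: the limit of > 20000 nM in this assay, at which 2 of the 4 values shown sit.

The compounds shown leave open whether another group on the same aromatic carbon of the core of compound 3, such as a hydroxyl or an acetamide, would also bring the number down, or whether amino is special there. They also leave open how far the result depends on the dimethylamino group, a question that a methoxy group in its place on the core of compound 4 would put to a direct test.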